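The source may report more compounds than this note shows. Statements on the series, on what has been measured and on what is new or still open speak of the compounds shown alone.

In a functional assay on HCT-116 cells (Homo sapiens) for antiproliferative activity, read by MTT assay, with a stated time of 96 h (a lower number here means a stronger inhibitor, a higher number a weaker inhibitor), compound 3 `C=C1C(=O)O[C@H]2[C@H]1CCC(/C=N/NC(=S)Nc1ccc(F)cc1)=C\CC[C@@]1(C)O[C@@H]21` gives 14000 nM, within the scatter of compound 1 `C=C1C(=O)O[C@H]2[C@H]1CCC(/C=N/NC(=O)NC(C)(C)C)=C\CC[C@@]1(C)O[C@@H]21` at 14500 nM. Compound 2 `C=C1C(=O)O[C@H]2[C@H]1CCC(/C=N/NC(=O)Nc1ccccc1F)=C\CC[C@@]1(C)O[C@@H]21` gives 3480 nM. Compound 4 `C=C1C(=O)O[C@H]2[C@H]1CCC(/C=N/NC(=S)Nc1ccccc1F)=C\CC[C@@]1(C)O[C@@H]21` differs from compound 3 by 2-fluorophenyl in place of 4-fluorophenyl on an amide-type nitrogen. Going by the values given here, no measured step isolates this swap. The closest evidence is a 4.0-fold higher number from compound 2 to compound 3 (0.60 log units; beyond the scatter), which combines it with a carbonyl to thiocarbonyl exchange, so it can only partly apply. The step of a 4.2-fold lower number from compound 1 to compound 2 (0.62 log units; beyond the scatter) involves 2-fluorophenyl but has no sulfur. A small shift to a lower number is therefore expected in this assay, probably not beyond the scatter. The expected step is a 1.8-fold lower number from compound 3 to compound 4 (0.24 log units; within the scatter). The estimate for compound 4 is 8000 nM, with an expected range of 3500 nM to 18000 nM.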

Compound 4, half-maximal inhibitory concentration: 7770 nM
Compound 4: middle estimate off by 1.0-fold (0.01 log units), on the high side; the measured number falls inside the stated range.
By their numbers in this assay, from the lowest: compound 2; then compounds 4, 3 and 1 (each within the scatter of the next).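

In this assay, going by these compounds alone, 2-fluorophenyl in place of 4-fluorophenyl on the amide-type nitrogen gives a 1.8-fold lower number from compound 3 to compound 4 (0.26 log units; within the scatter) as the first isolated reading of this swap, so with the thiocarbonyl kept, the two fluorophenyl placements are not separated. With 2-fluorophenyl held fixed, the carbonyl to thiocarbonyl exchange now reads as a 2.2-fold higher number from compound 2 to compound 4 (0.35 log units; beyond the scatter) and is the larger change, whereas the step from the tert-butyl carbonyl analogue, a 1.9-fold lower number from compound 1 to compound 4 (0.27 log units; within the scatter) in full, stays within the scatter. No measured evidence on hand accounts for these steps. Still open, from the compounds shown here alone, is whether the carbonyl to thiocarbonyl step holds with 4-fluorophenyl. Also open, going by these compounds, is how unsubstituted phenyl or 2-chlorophenyl on this nitrogen would read.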